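The source may hold more compounds than are shown below. What is called first, only, known or untested is meant among the compounds shown, and "the series" means these compounds.

Among the measured compounds shown here, compound 2 `Cc1nc(S(C)(=O)=O)ccc1Oc1ncnc(OC2CCN(C(=O)OC3COC3)CC2)c1F` stands at the higher end of the two numbers so far: in a functional assay on isolated protein for inhibition of Glucose-dependent insulinotropic receptor (Rattus norvegicus), read by HTRF and cAMP accumulation (a lower number here means that less compound is needed, a higher number that more compound is needed for the effect), compound 2 gives 2500 nM, while compound 1 `Cc1nc(S(C)(=O)=O)ccc1Oc1ncnc(OC2CCN(C(=O)OC(C)(C)CF)CC2)c1F` gives 138 nM in this assay. For the measured compounds named here, the only step measured is the one in which an 18-fold higher number from compound 1 to compound 2 (1.26 log units; beyond the scatter), the oxetan-3-yl ring taking the place of the 1-(fluoromethyl)-1-methylethyl group on the oxygen next to the carbonyl; it is large and runs toward a higher number.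

Compound 3 `Cc1nc(S(C)(=O)=O)ccc1Oc1ncnc(OC2CCN(C(=O)SC3CCC3)CC2)c1F` is reached from compound 2 by cyclobutylsulfanyl in place of (oxetan-3-yl)oxy on a carbonyl carbon. The change removes the four-membered ring with its ring oxygen and the linking oxygen and brings in a four-membered ring of carbon only, joined through sulfur. The step from compound 1 to compound 2 bears on this only indirectly, since it shows how sharply this position responds to exchanging the group on the carbonyl carbon, and the present change moves away from the group that gave the high number. A step toward a lower number in this assay is therefore expected for compound 3, of the size an 8.3-fold lower number from compound 2 to compound 3 (0.92 log units; beyond the scatter), though the absence of any direct comparison makes the range wide. Compound 3 is estimated at 300 nM, with a range from 90 nM to 1000 nM.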

Compound 3, half-maximal effective concentration: 77.4 nM
Compound 3: middle estimate off by 3.9-fold (0.59 log units), on the high side, outside the stated range (below it).
By their numbers in this assay, from the lowest: compounds 3 and 1 (each within the scatter of the next); then compound 2.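

In this assay, the step to cyclobutylsulfanyl on the carbonyl carbon gives a 32-fold lower number from compound 2 to compound 3 (1.51 log units; beyond the scatter) and so shows that this position can take a sulfur link and a four-membered ring of carbon only, and that a four-membered ring as such does not go with a high number here. The comparison with the open-chain fluorinated group shows a 1.8-fold lower number from compound 1 to compound 3 (0.25 log units; within the scatter) and so places two quite different groups, one with a ring and one without, on the same level in this assay. Nothing given here explains why the oxetan-3-yl compound stands so far from the other two.

The change from (oxetan-3-yl)oxy to cyclobutylsulfanyl replaces the linking atom and the ring oxygen together, so the compounds shown cannot say which of the two carries the step; cyclobutyloxy and oxetan-3-ylsulfanyl would separate them. As far as these compounds go, how a cyclobutylamino group on the same carbonyl carbon, or a longer carbon chain on the sulfur, would read in this assay also remains open.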